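Lengthening the chain from compound 2 to compound 3

This account rests on a few compounds, and the source may have more. Where it says the series, first, only, none or still open, it means among the compounds named here.

Compound 1 (`CCNc1c(N(C)CCCN(C)C)c(=O)c1=O`) gives 900000 nM
Compound 2 (`CCCCCCCCNc1c(N(C)CCCN(C)C)c(=O)c1=O`) gives 1150000 nM

Both values come from an ADME assay on Vero cells (Chlorocebus sabaeus) for cytotoxicity, read by resazurin assay, with a stated time of 72 h; a higher number here means a weaker inhibitor, a lower number a stronger inhibitor. Within the data shown here, compound 2 lies within the scatter of compound 1, the only other compound measured, so the two cannot be told apart. Compound 3 (`CCCCCCCCCCCCCCCCNc1c(N(C)CCCN(C)C)c(=O)c1=O`) keeps the core of compound 2 and carries a longer chain (octyl in place of hydrogen on a saturated chain carbon, eight bonds along the chain from a nitrogen on an aromatic ring).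

Among the measured compounds shown here, the one measured step that bears on this is also a chain extension, with hexyl in place of hydrogen on a saturated chain carbon (a 1.3-fold higher number from compound 1 to compound 2 (0.11 log units; within the scatter)). That step stayed within the scatter. For the measured compounds named here, it is only a single step, however, and the octyl added here gives a chain longer than any yet measured, so the data cannot show that the flat result continues. A real drop is therefore expected, though its size is poorly fixed, and the estimated change is a 7.7-fold lower number from compound 2 to compound 3 (0.88 log units; beyond the scatter). For compound 3 the estimated value is 150000 nM (expected range 10000 nM to 1000000 nM).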

Compound 3, half-maximal inhibitory concentration: 679000 nM
Compound 3: middle estimate off by 4.5-fold (0.66 log units), on the low side; the measured number falls inside the stated range.
By their numbers in this assay, from the lowest: compounds 3, 1 and 2 (each within the scatter of the next).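

In this assay, adding octyl on a saturated chain carbon, eight bonds along the chain from a nitrogen on an aromatic ring, gives a 1.7-fold lower number from compound 2 to compound 3 (0.23 log units; within the scatter) and so leaves the reading indistinguishable from no change. The earlier hexyl step (a 1.3-fold higher number from compound 1 to compound 2 (0.11 log units; within the scatter)) could have been a single flat result, but this second step shows the same outcome with a much longer chain, so two additions of plain carbon chain at this part of the molecule have now left the number within the scatter. Among the three compounds shown, chain length therefore gives no clear trend in this measurement, and no supporting measurement is available to explain that flat reading.

What the compounds leave open is whether this position stays as unresponsive when the added group is something other than a plain carbon chain, such as an amine, a carboxylic acid or a phenyl ring in place of the octyl. A still longer chain would also test whether the flat reading continues beyond compound 3.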